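Methoxy for Bromo on the Aryl Ring of Compound 3

The compounds below may be only part of what the source reports. "The series", "measured", "known", "first", "only" and "open" are said of these compounds alone.

Compound 1, `C=CCc1ccc(OCc2cn(-c3ccccc3Cl)nn2)c(O)c1`: 10.2%
Compound 2, `C=CCc1ccc(OCc2cn(-c3cccc(C#N)c3)nn2)c(O)c1`: 21.2%
Compound 3, `C=CCc1ccc(OCc2cn(-c3ccc(Br)cc3)nn2)c(O)c1`: 38.3%

Three compounds share one core and differ only in the aryl group on the aromatic nitrogen. In a functional assay on SK-N-SH cells (Homo sapiens) for inhibition, read by MTT assay, with a stated time of 72 h, tested at 30 uM (a lower number here means less inhibition of growth, a higher number more inhibition of growth at the concentration tested), compound 1 gives 10.2%, compound 2 gives 21.2% and compound 3 gives 38.3%. Compound 3 stands highest of the three, with a number 28.1 percentage points higher from compound 1 to compound 3 (beyond the scatter) and a number 17.1 percentage points higher from compound 2 to compound 3 (beyond the scatter); the remaining step is a number 11 percentage points higher from compound 1 to compound 2 (beyond the scatter).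

Compound 4, `C=CCc1ccc(OCc2cn(-c3ccc(OC)cc3)nn2)c(O)c1`, has not yet been tested in this assay. It differs from compound 3 by methoxy in place of bromo on an aromatic carbon. Among the compounds with values here, none of the measured steps swaps one group for another on the same aryl ring; all three exchange the whole aryl group, so they bear on the change only indirectly. They show that the 4-bromophenyl compound sits above the two others, and that the aryl group alone can move the number by a modest amount. Removing the bromo that marks the highest compound is therefore expected to give a modest step downward, or none beyond the scatter, with a number 12.3 percentage points lower from compound 3 to compound 4 (beyond the scatter) as the estimate. Compound 4 is thus expected to give about 26% in this assay, within the range 10% to 42%.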

Compound 4, percent growth inhibition at one concentration: 31.5%
Estimate against measurement, compound 4: 5.5 percentage points below; the measured number falls inside the stated range.
By their numbers in this assay, from the lowest: compound 1; then compound 2; then compounds 4 and 3 (each within the scatter of the next).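

In this assay, within the data shown here, the exchange of bromo for methoxy on this aromatic carbon, para to a large group, gives a number 6.8 percentage points lower from compound 3 to compound 4 (within the scatter) and is the first comparison made on the same aryl ring. Bromo is therefore not required to hold the number at the level of compound 3, and a group that brings a hydrogen-bond acceptor can take its place without a change beyond the scatter. The 4-methoxyphenyl group also stays clear of the other two aryl groups, with a number 10.3 percentage points higher from compound 2 to compound 4 (beyond the scatter) and a number 21.3 percentage points higher from compound 1 to compound 4 (beyond the scatter), so the separation seen for 4-bromophenyl is shared by a second, quite different group, although nothing shown explains why the two read alike.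

The compounds shown leave open whether the higher numbers follow the place of the group or its identity, since 2-chlorophenyl and 3-cyanophenyl differ from the others in both, and a 4-chlorophenyl group would separate the two. As far as these compounds go, it also remains open how far this place tolerates other groups, such as an amine, a carboxylic acid or a longer chain such as butoxy, or an unsubstituted phenyl ring.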